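The source may hold more compounds than are shown below. What is called first, only, known or untested is meant among the compounds shown, and "the series" means these compounds.

Three compounds of the series carry numbers in a functional assay on CHO cells for antagonist activity at Glucagon receptor (Homo sapiens), read by cAMP accumulation, with stated times of 30 min and 45 min; a higher number here means a weaker inhibitor, a lower number a stronger inhibitor. Compound 1 `C[C@H](c1ccc(C(=O)NCCC(=O)O)cc1)N1C(=O)C(c2cccc(C3CC3)c2)=N[C@]12CC[C@@H](C(C)(C)C)CC2` gives 340 nM. Compound 2 `CC(C)(C)[C@H]1CC[C@]2(CC1)N=C(c1cccc(C(F)(F)F)c1)C(=O)N2Cc1ccc(C(=O)NCCC(=O)O)cc1` gives 510 nM. Compound 3 `CC(C)[C@H](c1ccc(C(=O)NCc2nn[nH]n2)cc1)N1C(=O)C(c2cc(Cl)cc(Cl)c2)=N[C@]12CC[C@@H](C(C)(C)C)CC2` gives 2200 nM. Compound 2 holds the second highest of the three numbers; the nearest is compound 1, whose number sits within the scatter of that of compound 2, and the furthest is compound 3, whose number lies beyond the scatter. Compound 3 differs from compound 2 in several places at once, so the gap between them says nothing about any single change.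

Compound 4 `CC(C)(C)[C@H]1CC[C@]2(CC1)N=C(c1cccc(Cl)c1)C(=O)N2Cc1ccc(C(=O)NCCC(=O)O)cc1` has not yet been measured in this assay. It differs from compound 2 in one place: chloro in place of trifluoromethyl on an aromatic carbon. Within the data shown here, no pair of measured compounds isolates this change, so nothing in the numbers so far sets its size. The expectation is a small step, a 1.3-fold higher number from compound 2 to compound 4 (0.11 log units; within the scatter), not clearly beyond the scatter and, if anything, toward a higher number. Compound 4 is estimated at 650 nM, within 250 nM to 1700 nM.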

Compound 4, half-maximal inhibitory concentration: 770 nM
Compound 4: middle estimate off by 1.2-fold (0.07 log units), on the low side; the measured number falls inside the stated range.
By their numbers in this assay, from the lowest: compounds 1, 2 and 4 (each within the scatter of the next, the first and the last beyond it); then compound 3.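

In this assay, chloro in place of trifluoromethyl on this aromatic carbon gives a 1.5-fold higher number from compound 2 to compound 4 (0.18 log units; within the scatter). Among these compounds, this is the first single-place step, and it shows that 3-(trifluoromethyl)phenyl and 3-chlorophenyl cannot be told apart in this assay, even though the entering group has one heavy atom and the leaving group four. No measurement of any property of these groups bears on this result, so it stands as an observation without an explanation.

As far as these compounds go, it remains open whether a nitrile, a methoxy group or plain hydrogen on the same aromatic carbon would also give a number in this range. From the compounds shown here alone, it also remains open whether the same swap would read alike on the scaffolds of compound 1 and compound 3.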